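The compounds below may be only part of what the source reports. "The series", "measured", "known", "first", "only" and "open" are said of these compounds alone.

Compound 3 `O=C(CSC(=S)N1CCN(c2ccccc2)CC1)Nc1cccc(NC(=O)c2ccccn2)c1` carries a phenyl on the amine nitrogen in a ring of the shared core. In a functional assay on A549 cells (Homo sapiens) for antiproliferative activity, read by MTT assay, with a stated time of 48 h (on this read-out higher numbers stand for weaker inhibition and lower numbers for stronger inhibition), compound 3 gives 530 nM, the second highest of the three numbers recorded. Its nearest neighbour is compound 2 `O=C(CSC(=S)N1CCN(C2CCCCC2)CC1)Nc1cccc(NC(=O)c2ccccn2)c1`, which gives 390 nM in this assay; the step of a 1.4-fold higher number from compound 2 to compound 3 (0.13 log units; within the scatter) lies within the scatter. Furthest away is compound 1 `CCN1CCN(C(=S)SCC(=O)Nc2cccc(NC(=O)c3ccccn3)c2)CC1`, which gives 3720 nM; the steps of a 9.5-fold lower number from compound 1 to compound 2 (0.98 log units; beyond the scatter) and a 7.0-fold lower number from compound 1 to compound 3 (0.85 log units; beyond the scatter) are both beyond the scatter. Compound 4 `O=C(CSC(=S)N1CCN(c2ncccn2)CC1)Nc1cccc(NC(=O)c2ccccn2)c1` differs from compound 3 by one change: pyrimidin-2-yl in place of phenyl on an amine nitrogen in a ring. Among the compounds with values here, no measured step swaps one aromatic ring for another, so no direct precedent exists. The step that bears most closely, a 1.4-fold higher number from compound 2 to compound 3 (0.13 log units; within the scatter), shows that exchanging cyclohexyl for phenyl at this place left the number within the scatter, while only the ethyl of compound 1 stood apart. The step is therefore expected to be a 1.1-fold higher number from compound 3 to compound 4 (0.05 log units; within the scatter), none beyond the scatter. The estimate for compound 4 is 600 nM, in the range 250 nM to 1500 nM.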

Compound 4, half-maximal inhibitory concentration: 40 nM
Estimate against measurement, compound 4: 15-fold (1.18 log units) above, and the stated range ends above it.
By their numbers in this assay, from the lowest: compound 4; then compounds 2 and 3 (each within the scatter of the next); then compound 1.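

In this assay, within the data shown here, the earlier compounds had set only the ethyl apart, while cyclohexyl and phenyl on the amine nitrogen in a ring stayed within the scatter of each other. The step of a 13-fold lower number from compound 3 to compound 4 (1.12 log units; beyond the scatter) now shows that exchanging one six-membered aromatic ring for another at this position can matter greatly, so the match between cyclohexyl and phenyl did not mean that this position tolerates any ring equally. With a 9.8-fold lower number from compound 2 to compound 4 (0.99 log units; beyond the scatter) and a 93-fold lower number from compound 1 to compound 4 (1.97 log units; beyond the scatter) as well, pyrimidin-2-yl stands beyond the scatter from all three other groups, giving the lowest number of the four.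

From the compounds shown here alone, whether a single ring nitrogen, as in pyridin-2-yl, would give the same drop remains open, as does the effect of moving the ring nitrogens, as in pyrimidin-4-yl. Nothing presented here explains the size of this step.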